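The source may hold more compounds than are shown below. What is called first, only, known or untested is meant among the compounds shown, and "the series" means these compounds.

Measured set in a functional assay on PANC-1 cells (Homo sapiens) for cytotoxicity, read by WST assay, with a stated time of 24 h; a higher number here means a weaker inhibitor, a lower number a stronger inhibitor:
Compound 1 `O=C(/C=C/CCCCCCc1ccccc1)N1CCCC1`: compound 1 gives > 100000 nM, a limit of the assay.
Compound 2 `O=C(CCCCCCCCCCc1ccccc1)N1CCCCC1`: compound 2 gives > 100000 nM, a limit of the assay.
Compound 3 `O=C(CCCOCCCCc1ccccc1)N1CCCCC1`: compound 3 gives > 100000 nM, a limit of the assay.

Compound 2 therefore stands where every measured member stands: the limit of > 100000 nM in this assay, at which 3 of the 3 values shown sit. Going by the values given here, no compound shows a number, so no step between measured compounds can be sized, and the set gives no direction for any change.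

Compound 4 `O=C(CCCCCCCCc1cccc(Cl)c1)N1CCCCC1` differs from compound 2 by 3-chlorophenyl in place of phenethyl on a saturated chain carbon, eight bonds along the chain from a carbonyl carbon. Among the compounds with values here, with no measured step to lean on, the change in this assay from compound 2 to compound 4 is expected to be none beyond the scatter, most probably ending again at the limit. The step estimated here is a number no higher from compound 2 to compound 4 (the limit leaves the size open). In this assay compound 4 is expected at 100000 nM, within 30000 nM to 300000 nM.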

Compound 4, half-maximal inhibitory concentration: > 100000 nM
Compound 4 was reported as a limit; the forecaster's own chance of this, stated with the estimate: 80%; the middle value lies on the limit itself.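

Going by these compounds alone, compound 2 and compound 4 both sit at a limit of the assay, so no step between them can be read. The compounds shown leave open which change, if any, would give a measurable value in this assay.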